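A few compounds are considered here, and "the series" means these few. Any claim that something is new, unique, unknown or untested is made for them only; others in the source may bear on it.

Series of ureas on the shared core of compound 1 `O=C(Nc1ccc(Cl)cc1)Nc1ccc(Nc2ncnc3c2OCCN3)cc1`, followed in an assay on isolated protein for inhibition of proto-oncogene tyrosine-protein kinase receptor Ret (Homo sapiens), read by 33P incorporation, with stated times of 15 min and 40 min; on this read-out higher numbers stand for weaker inhibition and lower numbers for stronger inhibition. Compound 1 gives 3070 nM. Compound 2 `Cc1ccc(F)c(NC(=O)Nc2ccc(Nc3ncnc4c3OCCN4)cc2)c1` gives 1470 nM in this assay, a change of a 2.1-fold lower number from compound 1 to compound 2 (0.32 log units; beyond the scatter). Compound 3 `O=C(Nc1ccc(Nc2ncnc3c2OCCN3)cc1)Nc1cccc2ccccc12` only reaches the limit of > 10000 nM in this assay, at which 1 of the 3 values shown sits, in this assay. Compound 3 gives > 10000 nM, which is a limit and not a number. On these numbers compound 3 stands at the weak end of the three: the steps of an at least 3.2-fold higher number from compound 1 to compound 3 (0.51 log units; beyond the scatter) and an at least 6.8-fold higher number from compound 2 to compound 3 (0.83 log units; beyond the scatter) both run toward weaker inhibition as naphthalen-1-yl enters.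

Compound 4 `CC(C)(C)c1cc(NC(=O)Nc2ccc(Nc3ncnc4c3OCCN4)cc2)no1` is not yet measured. Its change from compound 3: 5-(tert-butyl)-1,2-oxazol-3-yl in place of naphthalen-1-yl on an amide-type nitrogen. Among the measured compounds shown here, no measured step covers this replacement directly; the two steps into compound 3 show that the single-ring aryl groups on this nitrogen gave measurable numbers where naphthalen-1-yl did not. For compound 4 a step of an at least 5.0-fold lower number from compound 3 to compound 4 (0.69 log units; beyond the scatter) toward stronger inhibition in this assay is therefore expected. Compound 4 is estimated at 2000 nM in this assay, with a range from 500 nM to 8000 nM.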

Compound 4, half-maximal inhibitory concentration: 10 nM
Estimate against measurement, compound 4: 200-fold (2.30 log units) above; measured number below the stated range.
By their numbers in this assay, from the lowest: compound 4; then compound 2; then compound 1. At a limit, above all of these: compound 3.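

Among the compounds shown here, on the amide-type nitrogen, this position spans a far wider range than the earlier compounds showed: 5-(tert-butyl)-1,2-oxazol-3-yl gives a 150-fold lower number from compound 2 to compound 4 (2.17 log units; beyond the scatter) and a 310-fold lower number from compound 1 to compound 4 (2.49 log units; beyond the scatter) in this assay, well past the steps among the earlier groups. The change into compound 4 also gives an at least 1000-fold lower number from compound 3 to compound 4 (3.00 log units; beyond the scatter), replacing two six-membered aromatic rings of carbon only with one five-membered aromatic ring with hetero atoms, so ring type and substituent change together. That step is a bound, since compound 3 stands at a limit and not at a number: the limit of > 10000 nM in this assay, at which 1 of the 4 values shown sits.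

The compounds shown do not separate the contribution of the tert-butyl group from that of the 1,2-oxazole ring. A phenyl ring bearing tert-butyl, or a 1,2-oxazol-3-yl ring bearing methyl instead of tert-butyl, would pull the two apart.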